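Serine to alanine on a purine glycinamide acid

This account rests on a few compounds, and the source may have more. Where it says the series, first, only, none or still open, it means among the compounds named here.

The series shares one core, carried here by compound 3 `O=C(CN(c1nc(Cl)nc2[nH]cnc12)C1CC1)N[C@@H](CO)C(=O)O`, the acid whose benzyl ester is compound 1 `O=C(CN(c1nc(Cl)nc2[nH]cnc12)C1CC1)N[C@@H](CO)C(=O)OCc1ccccc1` and whose proline analogue is compound 2 `O=C(OCc1ccccc1)[C@@H]1CCCN1C(=O)CN(c1nc(Cl)nc2[nH]cnc12)C1CC1`. In a functional assay on the whole organism (Tail, strain ICR) with Mus musculus as the target, in the tail flick test, with a stated time of 120 min, at a dose of 25 umol/kg by the oral route (a higher number here means a stronger effect of the compound at the dose given, a lower number a weaker effect), compound 3 gives 39%, the highest of the three numbers, while compound 2 gives 38.4% and compound 1 gives 34.5%; both lie within the scatter of compound 3. For the measured compounds named here, the only one-place step measured, a number 4.5 percentage points higher from compound 1 to compound 3 (within the scatter), is a change of hydrogen in place of benzyl on an oxygen next to a carbonyl group and stays within the scatter.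

Compound 4 `C[C@H](NC(=O)CN(c1nc(Cl)nc2[nH]cnc12)C1CC1)C(=O)O` differs from compound 3 by hydrogen in place of hydroxy on a saturated chain carbon, two bonds along the chain from an amide-type nitrogen and a carbonyl carbon. Going by the values given here, no measured step touches this position, so the account rests on the single step above, which was itself small, and on the closeness of all three numbers in this assay. The step is therefore expected to be a number 2 percentage points lower from compound 3 to compound 4 (within the scatter), with no direction claimed beyond the scatter. Compound 4 is estimated to give 37% in this assay, within a range from 20% to 54%.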

Compound 4, a percentage reported as activity, at one dose (the size of the read-out at that dose, not a potency): 28.4%
Compound 4: the middle estimate sits 8.6 percentage points above what was measured; the measured number falls inside the stated range.
By their numbers in this assay, from the lowest: compounds 4, 1, 2 and 3 (each within the scatter of the next, the first and the last beyond it).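

For the compounds shown here, the change of hydroxymethyl to methyl gives a number 10.6 percentage points lower from compound 3 to compound 4 (beyond the scatter) in this assay, and it is the first one-place step in this set to leave the scatter, whereas the earlier step, a number 4.5 percentage points higher from compound 1 to compound 3 (within the scatter), stayed inside it. The hydroxy on this saturated chain carbon is thus the first place where a single change moves the read-out, though the move is modest and rests on one pair of free acids, with compound 3 at 39% and compound 4 at 28.4%. No measurement on hand bears on why the number falls with the loss of the hydroxy.

The compounds shown leave open whether an amine or a methoxy group in place of the hydroxy, or a longer chain carrying the hydroxy, would hold the number of compound 3. They also leave open whether the same loss of hydroxy would count for as much on the benzyl ester, compound 1, and whether a step of this size would carry over to the proline analogue, compound 2, if a hydroxy were placed on its ring.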